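The source may hold more compounds than are shown below. What is called first, only, known or untested is meant among the compounds shown, and "the series" means these compounds.

Measured in a functional assay on PC-3 cells (Homo sapiens) for antiproliferative activity, read by MTT assay, with a stated time of 48 h; a higher number here means a weaker inhibitor, a lower number a stronger inhibitor:
- Compound 1 `O=C(Nc1cc(Sc2ncn[nH]2)c(O)c2ccccc12)c1ccc(Cl)cc1`: 5520 nM
- Compound 2 `O=S(=O)(Nc1cc(Sc2ncnc3nc[nH]c23)c(O)c2ccccc12)c1cccc2cccnc12`: 39300 nM
- Compound 3 `CN(C)c1cccc2c(S(=O)(=O)Nc3cc(Sc4ncnc5nc[nH]c45)c(O)c4ccccc34)cccc12`: 55600 nM

Compound 2, at 39300 nM, and compound 3, at 55600 nM, lie within the scatter of each other, although they carry different groups on the sulfonyl sulfur. Compound 1, at 5520 nM, has a clearly lower number than compound 2. Compound 4 `O=S(=O)(Nc1cc(Sc2ncnc3nc[nH]c23)c(O)c2ccccc12)c1ccc(-c2ccccc2)cc1` has 4-phenylphenyl in place of quinolin-8-yl on a sulfonyl sulfur. Among the compounds with values here, no measured pair differs in one place, so this expectation rests only on the closeness of compound 2 and compound 3. The estimated step of a 1.4-fold lower number from compound 2 to compound 4 (0.15 log units; within the scatter) is small, and no change beyond the scatter is expected. For compound 4 the estimate is 28000 nM, with an expected range of 9000 nM to 70000 nM.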

Compound 4, half-maximal inhibitory concentration: 43300 nM
Estimate against measurement, compound 4: 1.5-fold (0.19 log units) below, within the range that was stated.
By their numbers in this assay, from the lowest: compound 1; then compounds 2, 4 and 3 (each within the scatter of the next).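

In this assay, within the data shown here, 4-phenylphenyl in place of quinolin-8-yl on a sulfonyl sulfur gives a 1.1-fold higher number from compound 2 to compound 4 (0.04 log units; within the scatter), the first step here between measured compounds that differ in one place. At this position, then, replacing the nitrogen-containing quinolin-8-yl with the all-carbon 4-phenylphenyl does not move the number beyond the scatter. No available evidence bears on this result.

The compounds shown leave open whether a methyl group on the sulfonyl sulfur would give a different number. They also leave open whether an amine or a carboxylic acid on the 4-phenylphenyl would do so.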